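A Chlorophenyl Change on the Carbonyl Carbon

The compounds below may be only part of what the source reports. "The series", "measured", "known", "first", "only" and "open" are said of these compounds alone.

Of the compounds shown here, two with a shared core have been measured in a functional assay on NCI-H23 cells (Homo sapiens) for cytotoxicity, read by sulforhodamine B assay, with a stated time of 72 h; on this read-out higher numbers stand for weaker inhibition of growth and lower numbers for stronger inhibition of growth. Compound 1 `O=C(Nc1ccccc1O)C1CCc2ccccc2N1C(=O)c1ccccc1Cl` gives 46900 nM. Compound 2 `O=C(Nc1ccccc1C(F)(F)F)C1CCc2ccccc2N1C(=O)c1cccc(Cl)c1` gives 292 nM, the lower of the two numbers and beyond the scatter of compound 1. Compound 3 `O=C(Nc1ccccc1C(F)(F)F)C1CCc2ccccc2N1C(=O)c1ccccc1Cl` awaits measurement. It differs from compound 2 by a single change, (2-chlorophenyl in place of 3-chlorophenyl on a carbonyl carbon), which puts 2-chlorophenyl in place of 3-chlorophenyl on a carbonyl carbon. Within the data shown here, no step between measured compounds tests this change directly. Compound 1, at 46900 nM, also carries 2-chlorophenyl, and this is weak support for expecting a small move towards a higher number, near the edge of the scatter. The expected change is a 2.1-fold higher number from compound 2 to compound 3 (0.31 log units; beyond the scatter). For compound 3 the estimated value is 600 nM, with an expected range of 150 nM to 2500 nM.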

Compound 3, concentration for 50% growth inhibition: 2150 nM
Compound 3: the middle estimate sits 3.6-fold (0.55 log units) below what was measured; the range from low to high includes it.
By their numbers in this assay, from the lowest: compound 2; then compound 3; then compound 1.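

In this assay, 2-chlorophenyl in place of 3-chlorophenyl on a carbonyl carbon gives a 7.4-fold higher number from compound 2 to compound 3 (0.87 log units; beyond the scatter), so this first direct test shows that the number responds to where the chlorine sits, although the atoms stay the same. Trifluoromethyl in place of hydroxy on an aromatic carbon gives a 22-fold lower number from compound 1 to compound 3 (1.34 log units; beyond the scatter), which separates a second change from the one above, as compound 1 and compound 2 differ in both places. Nothing available explains either step.

As far as these compounds go, whether the hydroxy and trifluoromethyl step would hold with 3-chlorophenyl on the carbonyl carbon remains open. So does how a plain phenyl or a methoxyphenyl on that carbonyl carbon, or an amine or a nitrile in place of trifluoromethyl, would compare.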